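Aryl substituent exchange on the shared core

The source may report more compounds than this note shows. Statements on the series, on what has been measured and on what is new or still open speak of the compounds shown alone.

Measured so far:
compound 1 `CCOc1ccc(NC2=CC(=O)c3ncncc3C2=O)cc1` — 0.02 ug/mL
compound 2 `O=C1C(Nc2ccc(I)cc2)=CC(=O)c2ncncc21` — 0.04 ug/mL

In a functional assay on SK-OV-3 cells (Homo sapiens) for cytotoxicity, read by MTT assay, with a stated time of 72 h (on this read-out lower numbers stand for stronger inhibition and higher numbers for weaker inhibition), compound 1 gives 0.02 ug/mL while compound 2 gives 0.04 ug/mL. Compound 2 holds the higher of the two numbers, and its nearest neighbour is compound 1, separated by a 2.0-fold higher number from compound 1 to compound 2 (0.30 log units; within the scatter), so the two cannot be ordered on this read-out.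

Compound 3 `Cc1ccc(NC2=CC(=O)c3ncncc3C2=O)cc1` differs from compound 2 in one place: methyl in place of iodo on an aromatic carbon. Within the data shown here, the only measured step that bears on this position is a 2.0-fold higher number from compound 1 to compound 2 (0.30 log units; within the scatter), where one group on that aromatic carbon was exchanged for another without moving the number beyond the scatter. With no other comparison at hand, the exchange of iodo for methyl is expected to give a step of about no change at the digits printed from compound 2 to compound 3 (within the scatter) in this assay, that is, no change beyond the scatter in either direction. For compound 3 the estimate in this assay is 0.04 ug/mL, with a range of 0.015 ug/mL to 0.1 ug/mL.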

Compound 3, half-maximal inhibitory concentration: 0.03 ug/mL
For compound 3 the middle estimate is 1.3-fold (0.12 log units) above the measured one, within the range that was stated.
By their numbers in this assay, from the lowest: compounds 1, 3 and 2 (each within the scatter of the next).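

In this assay, methyl joins ethoxy and iodo on this aromatic carbon, para to a large group: the iodo-to-methyl exchange gives a 1.3-fold lower number from compound 2 to compound 3 (0.12 log units; within the scatter) and the ethoxy-to-methyl exchange gives a 1.5-fold higher number from compound 1 to compound 3 (0.18 log units; within the scatter) in the same series. All three exchanges among these groups now stay within the scatter, so the position accepts methyl, ethoxy and iodo alike on this read-out, and the three groups cannot be ordered. No measurement at hand accounts for this result.

From the compounds shown here alone, whether an amine, a carboxylic acid or a longer alkoxy chain on this carbon would move the number beyond the scatter remains open. Also open, going by these compounds, is whether any of these groups would give the same result at another position on the aromatic ring.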